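The source may report more compounds than this note shows. Statements on the series, on what has been measured and on what is new or still open speak of the compounds shown alone.

Measured so far in a functional assay on HCT-116 cells (Homo sapiens) for antiproliferative activity; on this read-out lower numbers stand for stronger inhibition and higher numbers for weaker inhibition:
- compound 1 `Cc1c2c(n3c1CCCN[C@@H](C)[C@H](C)Nc1cc-3ccc1C(N)=O)CC(C)(C)CC2=O`: 29 nM
- compound 2 `Cc1c2c(n3c1CCN(C)C[C@@H](C)[C@H](C)Nc1cc-3ccc1C(N)=O)CC(C)(C)CC2=O`: 27 nM
- compound 3 `Cc1c2c(n3c1CCCN(C(=O)CN)[C@@H](C)[C@H](C)Nc1cc-3ccc1C(N)=O)CC(C)(C)CC2=O`: 147 nM

Compound 2 and compound 1 lie within the scatter of each other, so neither can be ranked over the other, and the value of compound 3 is clearly higher than either.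

Compound 4 `Cc1c2c(n3c1CCN(C(=O)CN)C[C@@H](C)[C@H](C)Nc1cc-3ccc1C(N)=O)CC(C)(C)CC2=O` derives from compound 2, with (aminomethyl)carbonyl in place of methyl on an amine nitrogen in a ring.

Within the data shown here, one measured step bears on this change: a 5.1-fold higher number from compound 1 to compound 3 (0.70 log units; beyond the scatter). There the same group replaces hydrogen on an amine nitrogen in a ring. Among the measured compounds shown here, no measured step starts from methyl, and the two compounds carrying the nitrogen as in compound 2 have not yet been compared directly, so the parallel is only approximate. A step of similar size towards a higher number is nonetheless expected in this assay.

The expected change is a 5.2-fold higher number from compound 2 to compound 4 (0.71 log units; beyond the scatter). For compound 4 the estimated value is 140 nM, with an expected range of 60 nM to 320 nM.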

Compound 4, half-maximal inhibitory concentration: 216 nM
For compound 4 the middle estimate is 1.5-fold (0.19 log units) below the measured one, and the stated range covers the measured number.
By their numbers in this assay, from the lowest: compounds 2 and 1 (each within the scatter of the next); then compounds 3 and 4 (each within the scatter of the next).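

In this assay, placing (aminomethyl)carbonyl on the amine nitrogen in a ring gives an 8.0-fold higher number from compound 2 to compound 4 (0.90 log units; beyond the scatter), so the group raises the number when it replaces methyl, not only when it replaces hydrogen as in a 5.1-fold higher number from compound 1 to compound 3 (0.70 log units; beyond the scatter). The direction of the change therefore holds in both pairs shown, and neither pair goes against it. Nothing measured here accounts for this step.

The compounds shown leave open whether the higher number goes with the carbonyl or with the amine of the entering group, which an acetyl group or a 2-aminoethyl chain on this nitrogen would help to separate. They also leave open how a longer aminoacyl chain or a carboxylic acid at this nitrogen would read in this assay.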